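Swapping Dimethoxyphenyl Patterns on a Shared Core

The compounds below may be only part of what the source reports. "The series", "measured", "known", "first", "only" and "open" are said of these compounds alone.

Of the compounds shown here, three built on the same core have been measured in a functional assay on PC-3 cells (Homo sapiens) for cytotoxicity, read by MTT assay, with a stated time of 72 h; on this read-out lower numbers stand for stronger inhibition and higher numbers for weaker inhibition. Compound 1 `COc1ccc(/C=C/C(=O)Nc2cc3c(Nc4ccc(F)c(Cl)c4)ncnc3cc2OC)c(OC)c1` gives 38500 nM. Compound 2 `O=C(/C=C/c1ccc([N+](=O)[O-])cc1)Nc1cc2c(Nc3ccc(F)c(Cl)c3)ncnc2cc1O[C@H]1CCOC1` gives 22800 nM, and compound 3 `O=C(/C=C/c1cccc(Cl)c1Cl)Nc1cc2c(Nc3ccc(F)c(Cl)c3)ncnc2cc1O[C@H]1CCOC1` gives 27500 nM. Compound 1 carries the highest of the three numbers, but its gap to compound 3 and its gap to compound 2 both lie within the scatter, so the three compounds are not separated from one another.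

Among the compounds with values here, the only step between measured compounds that differ in a single place is a 1.2-fold higher number from compound 2 to compound 3 (0.08 log units; within the scatter), an exchange of the group on the double-bonded chain carbon that did not move the read-out beyond the scatter.

Compound 4 `COc1cc(/C=C/C(=O)Nc2cc3c(Nc4ccc(F)c(Cl)c4)ncnc3cc2OC)cc(OC)c1` differs from compound 1 by 3,5-dimethoxyphenyl in place of 2,4-dimethoxyphenyl on a double-bonded chain carbon bound to a double-bonded chain carbon. Within the data shown here, no measured step exchanges one dimethoxyphenyl for another, so the sole guide is the step from compound 2 to compound 3, where a different exchange at the same place left the number essentially where it was. The expected step for compound 4 in this assay is therefore a 1.2-fold lower number from compound 1 to compound 4 (0.08 log units; within the scatter), meaning no change beyond the scatter. Compound 4 is estimated at 32000 nM, within a range from 13000 nM to 80000 nM.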

Compound 4, half-maximal inhibitory concentration: "not active" (no number reported)
Nothing numeric was reported for compound 4, and the estimate cannot be compared.
By their numbers in this assay, from the lowest: compounds 2, 3 and 1 (each within the scatter of the next).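

In this assay, within the data shown here, compound 4 is reported only as not active, without a number, so no step from compound 1 to compound 4 can be read. No evidence at hand bears on this result. The compounds shown leave open how far 3,5-dimethoxyphenyl in place of 2,4-dimethoxyphenyl shifts the read-out.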